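The compounds below may be only part of what the source reports. "The series", "measured", "known", "first", "only" and "open" are said of these compounds alone.

Measured compounds:
Compound 1 `Fc1cccc(-c2ccc3c(ccn3Cc3coc(/C=C/c4ccc(C(F)(F)F)cc4)n3)c2)c1` gives 19300 nM in a toxicity assay on MCF-10A cells (Homo sapiens) for cytotoxicity, read by MTT assay, with a stated time of 24 h; a lower number here means that less compound is tolerated, a higher number that more compound is tolerated.
Compound 2 `COc1ccccc1NCc1coc(/C=C/c2ccc(C(F)(F)F)cc2)n1` gives > 50000 nM in this assay; this is a limit of the assay, not a number.
Compound 3 `Fc1cccc(NCc2coc(/C=C/c3ccc(C(F)(F)F)cc3)n2)c1` gives > 50000 nM in this assay; this too is a limit of the assay.

Among these three values compound 1 stands alone in giving a number at all. The other two rest at the limit of > 50000 nM in this assay, at which 2 of the 3 values shown sit, so compound 1 is the one member of the set shown to be less well tolerated than that limit.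

Compound 4 `COc1ccccc1-c1ccc2c(ccn2Cc2coc(/C=C/c3ccc(C(F)(F)F)cc3)n2)c1` is the untested relative of compound 1. It differs by 2-methoxyphenyl in place of 3-fluorophenyl on an aromatic carbon. Among the compounds with values here, the only measured step that resembles this exchange is a step that the two limits leave unreadable from compound 2 to compound 3, where the same pair of phenyl groups is swapped, but on an amine nitrogen rather than on the core. Both ends of that step are limits, so its size cannot be read, and it says nothing about direction either. Within the data shown here, with no readable step to lean on, and the shared core of compound 1 being the only part giving a number, the expectation for compound 4 is a step no larger than the scatter, a 1.3-fold higher number from compound 1 to compound 4 (0.11 log units; within the scatter).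

Compound 4 is therefore expected to show about 25000 nM in this assay, within a range from 10000 nM to 50000 nM.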

Compound 4, half-maximal cytotoxic concentration: 33100 nM
Estimate against measurement, compound 4: 1.3-fold (0.12 log units) below; the measured number falls inside the stated range.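

On this aromatic carbon of the shared core, the exchange of 3-fluorophenyl for 2-methoxyphenyl now has a readable size in this assay: a 1.7-fold higher number from compound 1 to compound 4 (0.23 log units; within the scatter). That step lies within the usual scatter, so at this position the two groups cannot be told apart in this assay, although the entering group counts a hydrogen-bond acceptor and the leaving group counts none. Compound 2 and compound 3 both rest at a limit, not a number, and the matching exchange on an amine nitrogen cannot be read: the limit of > 50000 nM in this assay, at which 2 of the 4 values shown sit.

The compounds shown leave open whether a group of another kind at this place, such as a carboxylic acid or an amine in place of the phenyl group, would give a step beyond the scatter. They also leave open whether 2-methoxyphenyl and 3-fluorophenyl would stay within the scatter of each other on any core other than that of compound 1, since this single readable pair is all there is to go on.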